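From 2-fluorophenyl to 3-fluorophenyl: compound 2 to compound 3

This account rests on a few compounds, and the source may have more. Where it says the series, first, only, none or still open, it means among the compounds named here.

In a functional assay on MDA-MB-231 cells (Homo sapiens) for antiproliferative activity, read by MTT assay, with a stated time of 48 h (on this read-out lower numbers stand for stronger inhibition and higher numbers for weaker inhibition), compound 1 `COc1ccc(NC(=O)N2CCN(c3ncnc4sc(-c5ccc(N6CCN(C)CC6)cc5)cc34)CC2)cc1` gives 20900 nM and compound 2 `CN1CCN(c2ccc(-c3cc4c(N5CCN(C(=O)Nc6ccccc6F)CC5)ncnc4s3)cc2)CC1` gives 10300 nM. Among the compounds with values here, compound 2 therefore holds the lower of the two numbers so far.

The next analogue is compound 3 `CN1CCN(c2ccc(-c3cc4c(N5CCN(C(=O)Nc6cccc(F)c6)CC5)ncnc4s3)cc2)CC1`, and its difference from compound 2 is 3-fluorophenyl in place of 2-fluorophenyl on an amide-type nitrogen. In short, 3-fluorophenyl stands in place of 2-fluorophenyl on an amide-type nitrogen.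

Within the data shown here, only one measured step bears on this change: a 2.0-fold lower number from compound 1 to compound 2 (0.31 log units; beyond the scatter). That modest step, on the same nitrogen, exchanged 4-methoxyphenyl for 2-fluorophenyl. Among the measured compounds shown here, no measured pair isolates a swap between fluorophenyl groups, so the evidence is thin. In this assay, no step beyond the scatter is expected, and no direction is favoured.

The expected change is a 1.0-fold lower number from compound 2 to compound 3 (0.01 log units; within the scatter). For compound 3 the estimated value is 10000 nM, with an expected range of 5000 nM to 20000 nM.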

Compound 3, half-maximal inhibitory concentration: 13200 nM
Compound 3: the middle estimate sits 1.3-fold (0.12 log units) below what was measured; low and high end bracket the measured number.
By their numbers in this assay, from the lowest: compounds 2, 3 and 1 (each within the scatter of the next, the first and the last beyond it).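

In this assay, 3-fluorophenyl in place of 2-fluorophenyl on the amide-type nitrogen gives a 1.3-fold higher number from compound 2 to compound 3 (0.11 log units; within the scatter), so the assay does not separate these two fluorophenyl groups. Compound 3 also stays within the scatter of compound 1, with a 1.6-fold lower number from compound 1 to compound 3 (0.20 log units; within the scatter), whereas a 2.0-fold lower number from compound 1 to compound 2 (0.31 log units; beyond the scatter) lies beyond it. Within the data shown here, the only separation among the three compounds is therefore the one between compound 1 and compound 2, and it is modest.

From the compounds shown here alone, it remains open whether 4-fluorophenyl, unsubstituted phenyl or a phenyl ring bearing a carboxylic acid on this nitrogen would fall outside the scatter of compound 2. Going by these compounds, it is equally open whether any change elsewhere on the shared core would produce a larger step than those seen here. No measurement available here accounts for these numbers.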